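A hydroxy substituent steps from a bare phenyl ring

A few compounds are considered here, and "the series" means these few. Any claim that something is new, unique, unknown or untested is made for them only; others in the source may bear on it.

Compound 1 `O=C(N/N=C/c1ccccc1)c1cnccn1` is the parent of this small set. In an ADME assay on J774 cells (Mus musculus) for cytotoxicity, read by MTT assay, with a stated time of 48 h, tested at 100 ug/mL (a higher number here means a weaker effect of the compound at the concentration tested, a lower number a stronger effect), compound 1 gives 75%, the lowest of the three numbers measured. Compound 2 `O=C(N/N=C/c1ccccc1F)c1cnccn1` gives 100% in this assay, and compound 3 `COc1ccccc1/C=N/NC(=O)c1cnccn1` gives 100%. The two substituted analogues thus sit together, with no change at the digits printed from compound 2 to compound 3 (within the scatter).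

Compound 4 `O=C(N/N=C/c1cccc(O)c1)c1cnccn1` has not yet been measured. It differs from compound 1 by hydroxy in place of hydrogen on an aromatic carbon. The measured steps that bear on this change are both substitutions of a hydrogen on the same aromatic carbon type: a number 25 percentage points higher from compound 1 to compound 2 (beyond the scatter) and a number 25 percentage points higher from compound 1 to compound 3 (beyond the scatter). Each of those substitutions raised the number by the same modest amount, so a rise of similar size is expected for a hydroxy group entering in place of a hydrogen, with the estimate a number 17 percentage points higher from compound 1 to compound 4 (beyond the scatter). Compound 4 is therefore expected to give 92% in this assay, within a range of 72% to 105%.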

Compound 4, a percentage reported as activity, at one concentration (the size of the read-out at that concentration, not a potency): 100%
Compound 4: middle estimate off by 8 percentage points, on the low side, and the stated range covers the measured number.
By their numbers in this assay, from the lowest: compound 1; then compounds 2, 3 and 4 (each within the scatter of the next).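

In this assay the hydroxy group, placed on an aromatic carbon meta to a large group, gives a number a number 25 percentage points higher from compound 1 to compound 4 (beyond the scatter) and so matches in size the steps seen with fluoro and methoxy. A third kind of substituent, and the first here with a hydrogen-bond donor, therefore leaves compound 1 with the lowest number of the set, while compounds 2, 3 and 4 cannot be told apart within the scatter. Among these compounds, the assay separates the unsubstituted phenyl ring from the substituted ones but does not distinguish among the three substituents.

As far as these compounds go, whether an amine or a carboxylic acid in the same place would give the same number remains open, as does the effect of hydroxy on another carbon of the ring. Nothing available accounts for the rise seen with any of these substituents.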